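Changing the Amide Substituent of Compound 1

This account rests on a few compounds, and the source may have more. Where it says the series, first, only, none or still open, it means among the compounds named here.

Measured compounds:
Compound 1 `CCN(CC)S(=O)(=O)c1ccc(S(=O)(=O)N2CCC[C@@H](C(=O)NC3CN(C(=O)C4CC4)C3)C2)cc1`: 18500 nM
Compound 2 `CCN(CC)C(=O)[C@@H]1CCCN(S(=O)(=O)c2ccc(S(=O)(=O)N(CC)CC)cc2)C1`: 10500 nM

In a functional assay on BXPC-3 cells (Homo sapiens) for inhibition, read by MTT assay, with a stated time of 7 days (a lower number here means a stronger inhibitor, a higher number a weaker inhibitor), compound 1 gives 18500 nM, the highest of the two numbers seen so far. Its nearest neighbour, compound 2, gives 10500 nM, and the step of a 1.8-fold lower number from compound 1 to compound 2 (0.25 log units; within the scatter) stays within the scatter, so the two compounds cannot be ordered. Compound 3 `CCN(CC)S(=O)(=O)c1ccc(S(=O)(=O)N2CCC[C@@H](C(=O)N[C@H]3CCN(C(=O)OC(C)(C)C)C3)C2)cc1` has not yet been measured. It differs from compound 1 in one place: 1-(tert-butoxycarbonyl)pyrrolidin-3-yl in place of 1-(cyclopropylcarbonyl)azetidin-3-yl on an amide-type nitrogen. Going by the values given here, the only measured step bears on this same place, since from compound 1 to compound 2 the group on the carbonyl carbon was also exchanged, and that step did not move the number beyond the scatter. Among the compounds with values here, no measured step covers the group that enters here. Compound 3 is therefore expected to land close to compound 1, with an expected step of a 1.2-fold lower number from compound 1 to compound 3 (0.09 log units; within the scatter). Compound 3 is estimated at 15000 nM, in the range 5000 nM to 45000 nM.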

Compound 3, half-maximal inhibitory concentration: 300 nM
Compound 3: middle estimate off by 50-fold (1.70 log units), on the high side; the measured number lies below the stated range.
By their numbers in this assay, from the lowest: compound 3; then compounds 2 and 1 (each within the scatter of the next).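

In this assay the group on the amide-type nitrogen proves able to shift the number strongly: 1-(tert-butoxycarbonyl)pyrrolidin-3-yl in place of 1-(cyclopropylcarbonyl)azetidin-3-yl gives a 62-fold lower number from compound 1 to compound 3 (1.79 log units; beyond the scatter) and so goes far beyond the earlier exchange on this amide, which gave a 1.8-fold lower number from compound 1 to compound 2 (0.25 log units; within the scatter) and stayed within the scatter. The new group differs from the old one in several ways at once, in ring size, in the carbonyl-bearing group on the ring nitrogen and in a defined stereocentre, so this single step cannot assign the gain to any one of them. Nothing shown gives a measured reason for the size of this step.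

The compounds shown leave open whether the tert-butoxycarbonyl group or the pyrrolidin-3-yl ring matters more. A pyrrolidin-3-yl carrying cyclopropylcarbonyl, an azetidin-3-yl carrying tert-butoxycarbonyl, or a pyrrolidin-3-yl with a free amine would separate these parts.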